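Trimming the amine chain of compound 2 down to a urea

The compounds below may be only part of what the source reports. "The series", "measured", "known", "first", "only" and "open" are said of these compounds alone.

Compound 1, with structure `N=C(N)NC(=O)Nc1cccc(Cl)c1`, is the stronger of the two measured compounds: in an in vitro assay on NG 108-15 cells for binding affinity to Serotonin 3 (5-HT3) receptor (Homo sapiens) (a lower number here means a stronger inhibitor, a higher number a weaker inhibitor), compound 1 gives 1250 nM. Compound 2, with structure `NCCC(=O)Nc1cccc(Cl)c1`, is known only by a limit: in this assay compound 2 gives > 10000 nM, which is a limit of the assay and not a number. Within the data shown here, the one measured step, an at least 8.0-fold higher number from compound 1 to compound 2 (0.90 log units; beyond the scatter), shows that the change at the carbonyl carbon made the binding clearly weaker, as noted in the limit of > 10000 nM in this assay, at which 1 of the 2 values shown sits. Compound 3, with structure `NC(=O)Nc1cccc(Cl)c1`, differs from compound 2 by amino in place of 2-aminoethyl on a carbonyl carbon, so the chain is shortened to the smallest possible group while the carbonyl and its amide-type nitrogen stay. Among the measured compounds shown here, no measured pair mirrors this shortening, so the direction of the step is uncertain. Compound 3 is expected to remain a weak binder, estimated at 8000 nM with a range from 1500 nM to 30000 nM.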

Compound 3, inhibition constant: > 10000 nM
Compound 3 ended at the assay's limit (the forecaster's own chance of this, stated with the estimate: 45%); at least 1.2-fold (0.09 log units) between middle value and limit.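

Replacing the group on the amide-type nitrogen with a hydrogen atom gives an at least 8.0-fold higher number from compound 1 to compound 3 (0.90 log units; beyond the scatter) in this assay. The bare urea therefore does not keep the binding seen with compound 1, so the carbonyl and its amide-type nitrogen are not enough on their own in this assay. Swapping 2-aminoethyl for amino on the carbonyl carbon brings no measurable recovery, and the step between compound 2 and compound 3 cannot be read because both compounds stop at the same assay limit: the limit of > 10000 nM in this assay, at which 2 of the 3 values shown sit.

From the compounds shown here alone, how much weaker compound 2 and compound 3 really are remains open, since a limit is not a number. Going by these compounds, it is also open whether a methyl, an acetyl or a longer amine chain on the amide-type nitrogen would restore binding.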